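The source may report more compounds than this note shows. Statements on the series, on what has been measured and on what is new or still open speak of the compounds shown alone.

Measured compounds in the series:

compound 1, `CN(C)c1c(C(=O)c2ccccc2)sc2nc(-c3cccs3)ccc12`: > 4 ug/mL
compound 2, `COc1ccc(C(=O)c2sc3nc(-c4cccs4)ccc3c2N)c(OC)c1`: 0.52 ug/mL
compound 3, `COc1ccc(OC)c(C(=O)c2sc3nc(-c4cccs4)ccc3c2N)c1`: 0.079 ug/mL

Compound 1 gives only a limit in a functional assay on WI-38 VA13 cells (Homo sapiens) for cytotoxicity (on this read-out higher numbers stand for an effect only at larger amounts of compound and lower numbers for an effect already at smaller amounts), namely (the limit of > 4 ug/mL in this assay, at which 1 of the 3 values shown sits), and no number. Of the two numbers available, compound 2 stands at 0.52 ug/mL and compound 3, the lower of the two, at 0.079 ug/mL; the gap between compound 2 and compound 3 lies beyond the usual scatter of this assay. Going by the values given here, compound 3 thus marks the strongest effect among the numbers so far.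

Compound 4, `COc1cccc(C(=O)c2sc3nc(-c4cccs4)ccc3c2N)c1`, is not yet measured. It differs from compound 3 by hydrogen in place of methoxy on an aromatic carbon, ortho to the large group and para to the remaining methoxy group. Since the two dimethoxy compounds differ substantially from each other in this assay, the single-methoxy compound 4 is expected to move as well, most likely toward a larger number. A step of a 6.3-fold higher number from compound 3 to compound 4 (0.80 log units; beyond the scatter) is expected. Compound 4 is estimated at 0.5 ug/mL, with a range from 0.15 ug/mL to 2 ug/mL.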

Compound 4, half-maximal effective concentration: 0.03 ug/mL
The estimate for compound 4 lay 17-fold (1.22 log units) above the measured number; measured number below the stated range.
By their numbers in this assay, from the lowest: compound 4; then compound 3; then compound 2. At a limit, above all of these: compound 1.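

Taking away the methoxy group ortho to the large group does not weaken the effect in this assay: hydrogen in its place gives a 2.6-fold lower number from compound 3 to compound 4 (0.42 log units; beyond the scatter), a modest step. Going by these compounds, in this pair, the methoxy group at this position is therefore not required for activity, while the methoxy group para to it stays in both compounds and its own share remains untested. Nothing measured here accounts for the direction of this step.

On these data alone, whether hydrogen is the best group at this position stays open, as a hydroxyl, a fluorine or an amine there could move the number either way. Also open, as far as these compounds go, is what happens with hydrogen in place of the remaining methoxy group, or with that methoxy group exchanged for a longer chain such as propoxy.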